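The compounds below may be only part of what the source reports. "The series", "measured", "known", "first", "only" and "open" are said of these compounds alone.

Compound 3 `COc1ccc(C(=O)Nc2cccc(/C=C/C(=O)c3nc4ccccc4[nH]3)c2)cc1` gives 6330 nM in a functional assay on 143B cells (Homo sapiens) for antiproliferative activity, read by MTT assay, with a stated time of 48 h (on this read-out lower numbers stand for stronger inhibition and higher numbers for weaker inhibition), the highest of the three numbers in hand, yet its nearest neighbour is compound 1 `O=C(/C=C/c1cccc(NC(=O)c2ccccc2Br)c1)c1nc2ccccc2[nH]1` with 6050 nM and its furthest is compound 2 `O=C(Nc1cccc(/C=C/C(=O)c2nc3ccccc3[nH]2)c1)c1cccc(Br)c1` with 4620 nM; both gaps stay within the scatter. Compound 4 `Cc1ccc(S(=O)(=O)Nc2cccc(/C=C/C(=O)c3nc4ccccc4[nH]3)c2)cc1` differs from compound 3 by (4-methylphenyl)sulfonyl in place of (4-methoxyphenyl)carbonyl on a nitrogen on an aromatic ring. Among the compounds with values here, the steps that bear on this change all vary the group on the same nitrogen: a 1.0-fold higher number from compound 1 to compound 3 (0.02 log units; within the scatter) and a 1.4-fold higher number from compound 2 to compound 3 (0.14 log units; within the scatter), with a 1.3-fold lower number from compound 1 to compound 2 (0.12 log units; within the scatter) alongside. None left the scatter, so the group on this nitrogen has so far mattered little. Within the data shown here, no measured step exchanges a carbonyl for a sulfonyl here, so the expectation rests on that flat record. Compound 4 is therefore expected to show a 1.1-fold lower number from compound 3 to compound 4 (0.02 log units; within the scatter), giving an estimate of 6000 nM with a range of 2500 nM to 15000 nM.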

Compound 4, half-maximal inhibitory concentration: 3220 nM
Compound 4: the middle estimate sits 1.9-fold (0.27 log units) above what was measured; measured number inside the range.
By their numbers in this assay, from the lowest: compounds 4, 2, 1 and 3 (each within the scatter of the next).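

In this assay, within the data shown here, a sulfonyl in place of a carbonyl on this nitrogen, an exchange the earlier compounds did not cover, gives a 2.0-fold lower number from compound 3 to compound 4 (0.29 log units; within the scatter) as the widest step on this nitrogen so far, yet it stays within the scatter. The other two exchanges give a 1.4-fold lower number from compound 2 to compound 4 (0.16 log units; within the scatter) and a 1.9-fold lower number from compound 1 to compound 4 (0.27 log units; within the scatter) and also stay within it, so the flat record at this position extends to the sulfonyl link. No evidence bearing on these numbers is at hand. Going by these compounds, whether an amine, a carboxylic acid or a longer chain on this nitrogen would move the number beyond the scatter remains open.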